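The source may hold more compounds than are shown below. What is called first, only, known or untested is meant among the compounds shown, and "the series" means these compounds.

Three compounds share one core. Compound 1 `COc1ccccc1Nc1nc(-c2cccc(F)c2)nc2ccc(F)cc12` gives in a functional assay on MDA-MB-231 cells (Homo sapiens) for cytotoxicity, read by MTT assay, with a stated time of 48 h (a lower number here means a stronger inhibitor, a higher number a weaker inhibitor), only a limit of the assay, > 50000 nM. Compound 2 `Fc1ccc(Nc2nc(-c3cccc(F)c3)nc3ccc(F)cc23)cc1` likewise reaches only the limit in this assay, > 50000 nM. Going by the values given here, compound 3 `Fc1cccc(Nc2nc(-c3cccc(F)c3)nc3ccc(F)cc23)c1` is the one compound with a number in this assay, at 47600 nM. The steps to it, an at least 1.0-fold lower number from compound 1 to compound 3 (0.02 log units; that floor lies within the scatter) and an at least 1.0-fold lower number from compound 2 to compound 3 (0.02 log units; that floor lies within the scatter), are floors lying within the scatter, and the step that the two limits leave unreadable from compound 1 to compound 2 cannot be sized, given (the limit of > 50000 nM in this assay, at which 2 of the 3 values shown sit). Compound 4 `Fc1cccc(-c2nc(Nc3ccccc3F)c3cc(F)ccc3n2)c1` differs by 2-fluorophenyl in place of 3-fluorophenyl on a nitrogen on an aromatic ring. Among the compounds with values here, with no measured step covering this move, and the nearest ones, an at least 1.0-fold lower number from compound 2 to compound 3 (0.02 log units; that floor lies within the scatter) and an at least 1.0-fold lower number from compound 1 to compound 3 (0.02 log units; that floor lies within the scatter), showing no readable effect, a step of a 1.2-fold higher number from compound 3 to compound 4 (0.06 log units; within the scatter) is expected in this assay. Compound 4 is therefore estimated at 55000 nM, between 20000 nM and 150000 nM, with a fair chance that only a limit is reported.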

Compound 4, half-maximal inhibitory concentration: > 50000 nM
Compound 4 was reported as a limit (the forecaster's own chance of this, stated with the estimate: 55%); the middle value lies beyond the limit too.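

In this assay, changing 3-fluorophenyl to 2-fluorophenyl on the nitrogen gives an at least 1.0-fold higher number from compound 3 to compound 4 (0.02 log units; that floor lies within the scatter). The 2-fluorophenyl, 3-fluorophenyl and 4-fluorophenyl groups at this place are therefore not told apart, and the steps to compound 4 from compound 1 and from compound 2 cannot be read. The series now sits almost entirely at one edge of the readable range: the limit of > 50000 nM in this assay, at which 3 of the 4 values shown sit.

As far as these compounds go, it remains open whether any other group on this nitrogen would give a number clearly away from that limit in this assay. A chlorophenyl, or a phenyl carrying an amine or a carboxylic acid, could test this.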